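Swapping an Aminopropyl Arm for an Aminoacetyl Group

This account rests on a few compounds, and the source may have more. Where it says the series, first, only, none or still open, it means among the compounds named here.

Compound 3 `CCC(C)[C@H](NC[C@H](C)N)c1cc(C(F)(F)F)ccc1N1CCN(C(=O)CCc2ccc(Cl)cc2Cl)CC1` gives 89 nM in an assay on HEK293 cells for displacement of a labelled ligand from Melanocortin receptor 4 (Homo sapiens) (a lower number here means a stronger inhibitor, a higher number a weaker inhibitor), and holds the lowest of the two numbers recorded. Compound 1 `CCCCC(N)c1cc(C(F)(F)F)ccc1N1CCN(C(=O)CCc2ccc(Cl)cc2Cl)CC1` gives 190 nM in this assay; the corresponding step is a 2.1-fold lower number from compound 1 to compound 3 (0.33 log units; beyond the scatter). Compound 2 `CCC(C)[C@H](NCc1ccccc1F)c1cc(C(F)(F)F)ccc1N1CCN(C(=O)CCc2ccc(Cl)cc2Cl)CC1` reaches only the limit of this assay, > 10000 nM. The step of an at least 110-fold lower number from compound 2 to compound 3 (2.05 log units; beyond the scatter) shows that the group carried by this amine nitrogen weighs heavily on the result. Compound 4 `CCC(C)[C@H](NC(=O)CN)c1cc(C(F)(F)F)ccc1N1CCN(C(=O)CCc2ccc(Cl)cc2Cl)CC1` differs from compound 3 in exactly one place: (aminomethyl)carbonyl in place of 2-aminopropyl on an amine nitrogen. Both measured steps altered this same position, one modestly and one very strongly, so a moderate loss is expected, a 3.9-fold higher number from compound 3 to compound 4 (0.59 log units; beyond the scatter). Compound 4 is therefore estimated at 350 nM, with a plausible range from 80 nM to 2500 nM.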

Compound 4, inhibition constant: 18 nM
Estimate against measurement, compound 4: 19-fold (1.29 log units) above; measured number outside the range, below it.
By their numbers in this assay, from the lowest: compound 4; then compound 3; then compound 1. At a limit, above all of these: compound 2.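

Putting a carbonyl on this amine nitrogen, with the heavy-atom count unchanged, brings a gain rather than a loss: a 4.9-fold lower number from compound 3 to compound 4 (0.69 log units; beyond the scatter). Replacing 1-aminopentyl with 1-(((aminomethyl)carbonyl)amino)-2-methylbutyl gives an 11-fold lower number from compound 1 to compound 4 (1.02 log units; beyond the scatter), a change that alters the carbon chain as well. Against the 2-fluorobenzyl group the change gives an at least 550-fold lower number from compound 2 to compound 4 (2.74 log units; beyond the scatter), and that step rests on a limit, not a number: the limit of > 10000 nM in this assay, at which 1 of the 4 values shown sits.

The change adds the carbonyl and removes the defined stereocentre together, and the compounds shown do not separate the two. On these data alone, how a longer chain before the terminal amine, or a carboxylic acid in its place, would read remains open.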